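A few compounds are considered here, and "the series" means these few. Any claim that something is new, unique, unknown or untested is made for them only; others in the source may bear on it.

Compound 1 `CCC1(CCCCN2CCN(c3ccc(C)c(Cl)c3)CC2)C(=O)Nc2ccccc21` gives > 20 mg/kg in a functional assay on the whole organism (strain Wistar) with Rattus norvegicus as the target, with a stated time of 5 min (on this read-out lower numbers stand for an effect already at smaller amounts and higher numbers for an effect only at larger amounts of compound), which is a limit of the assay and not a measured number. Compound 2 `O=C1Nc2ccc(F)cc2C1CCCCN1CCN(c2ccc(F)cc2)CC1` gives > 10 mg/kg in this assay, again only a limit. Compound 3 `CCC1(CCCCN2CCN(c3ccc(Cl)cc3)CC2)C(=O)Nc2cc(F)c(Cl)cc21` has the entry "not determined" (no result reported) in this assay, that is, no result was reported for it.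

Three compounds were thus tested in this assay. Compound 1 therefore stands nowhere on a scale of numbers: what is known of it is the limit of > 20 mg/kg in this assay, at which 1 of the 3 values shown sits, and the only other entry with a sign is the limit of > 10 mg/kg in this assay, at which 1 of the 3 values shown sits. Going by the values given here, no pair of measured compounds differs in a single place, so no step of known size is available.

Compound 4 `CCC1(CCCCN2CCN(c3cccc(Cl)c3)CC2)C(=O)Nc2ccccc21` is the next compound to be measured. It differs from compound 1 in one place: hydrogen in place of methyl on an aromatic carbon. Since nothing measured shows how such a change moves this read-out, no step beyond the usual scatter is expected. The step from compound 1 is estimated as a step that the limit leaves unreadable from compound 1 to compound 4. Compound 4 is expected to give about 30 mg/kg in this assay. The range of that estimate for compound 4 runs from 10 mg/kg to 100 mg/kg, and it is likely that the assay will again report only a limit.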

Compound 4, minimum effective dose: > 20 mg/kg
Compound 4: only a limit was reported; the forecaster's own chance of this, stated with the estimate: 70%; the middle value does not contradict the limit.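

Compound 1 and compound 4 each give only a limit in this assay, not a measured number, and the size of the step on going from the 3-chloro-4-methylphenyl group to the 3-chlorophenyl group cannot be read. The compounds shown leave open at what dose any of them acts in this assay, and whether that methyl matters to this read-out.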